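Naphthalenyl for methylphenyl on the ether oxygen of compound 1

The source may hold more compounds than are shown below. What is called first, only, known or untested is meant among the compounds shown, and "the series" means these compounds.

Measured so far:
compound 1 `Cc1ccc(OCc2nnc(S)n2N2C(=O)CSC2c2c[nH]nc2-c2ccc(F)cc2)cc1` — > 100 ug/mL
compound 2 `COc1ccc(-c2n[nH]cc2C2SCC(=O)N2n2c(S)nnc2COc2ccc(C)cc2)cc1` — 78 ug/mL

In a functional assay on MCF7 cells (Homo sapiens) for inhibition, read by MTT assay, with a stated time of 24 h (a lower number here means a stronger inhibitor, a higher number a weaker inhibitor), compound 1 reaches only the assay limit, (the limit of > 100 ug/mL in this assay, at which 1 of the 2 values shown sits), so no number stands for it. Compound 2, a methoxy-for-fluoro variant, gives 78 ug/mL; the step of an at least 1.2-fold lower number from compound 1 to compound 2 (0.10 log units; that floor lies within the scatter) sits at a different place and does not bear on the change considered here. Compound 3 `O=C1CSC(c2c[nH]nc2-c2ccc(F)cc2)N1n1c(S)nnc1COc1ccc2ccccc2c1` differs from compound 1 by naphthalen-2-yl in place of 4-methylphenyl on an oxygen on a saturated carbon. For the measured compounds named here, no measured step touches this position, so no direction beyond the scatter is predicted in this assay. Compound 3 is expected near 90 ug/mL, within 40 ug/mL to 200 ug/mL. The expected step is an at least 1.1-fold lower number from compound 1 to compound 3 (0.04 log units; that floor lies within the scatter).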

Compound 3, half-maximal inhibitory concentration: > 100 ug/mL
Compound 3 ended at the assay's limit; the forecaster's own chance of this, stated with the estimate: 50%; middle value at least 1.1-fold (0.04 log units) from the limit.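

Compound 3 gives > 100 ug/mL in this assay, which is a limit and not a number. Compound 1 also sits at a limit, so no step from it to compound 3 can be read: the limit of > 100 ug/mL in this assay, at which 2 of the 3 values shown sit.

Going by these compounds, whether naphthalen-2-yl in place of 4-methylphenyl shifts the value in either direction stays open.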